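Moving the fluoro group from compound 3 to compound 4

This account rests on a few compounds, and the source may have more. Where it says the series, first, only, none or still open, it means among the compounds named here.

In an ADME assay on THP-1 cells (Homo sapiens) for cytotoxicity, read by flow cytometry and propidium iodide staining, with a stated time of 72 h (on this read-out higher numbers stand for weaker inhibition and lower numbers for stronger inhibition), compound 1 (`CC(=O)Nc1ccc(O)c(C(=O)/C=C/c2ccccc2)c1`) gives 85500 nM and compound 2 (`COc1cccc(/C=C/C(=O)c2cc(NC(C)=O)ccc2O)c1`) gives 93700 nM as measured numbers. Compound 3 (`CC(=O)Nc1ccc(O)c(C(=O)/C=C/c2ccccc2F)c1`) gives > 125000 nM as a limit of the assay and not a number.

Compound 4 (`CC(=O)Nc1ccc(O)c(C(=O)/C=C/c2ccc(F)cc2)c1`) has not been measured yet. It has the same atoms as compound 3, joined differently, with 4-fluorophenyl in place of 2-fluorophenyl on a double-bonded chain carbon bound to a double-bonded chain carbon.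

Among the measured compounds shown here, two measured steps bear on this change. Methoxy in place of hydrogen on an aromatic carbon gives a 1.1-fold higher number from compound 1 to compound 2 (0.04 log units; within the scatter) and fluoro in place of hydrogen on an aromatic carbon gives an at least 1.4-fold higher number from compound 1 to compound 3 (0.16 log units; that floor lies within the scatter) as the second step. Neither is shown to go beyond the scatter, although no measured step swaps one fluorophenyl for another.

With only these small steps to go on, no step beyond the scatter is expected in this assay and no firm direction can be given. The estimated step is an at least 1.2-fold lower number from compound 3 to compound 4 (0.09 log units; that floor lies within the scatter) and it should be read as an expectation only. For compound 4 the expected value is 100000 nM with an estimated range from 65000 nM to 150000 nM.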

Compound 4, half-maximal inhibitory concentration: 68800 nM
The estimate for compound 4 lay 1.5-fold (0.16 log units) above the measured number; the measured number falls inside the stated range.
By their numbers in this assay, from the lowest: compounds 4, 1 and 2 (each within the scatter of the next). At a limit, above all of these: compound 3.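

In this assay, 4-fluorophenyl gives the first measured number for a fluorophenyl group on this chain carbon, and setting it in place of the plain phenyl group gives a 1.2-fold lower number from compound 1 to compound 4 (0.09 log units; within the scatter), so fluoro in this form has not been shown to change the result. Among the compounds shown here, the swap of 2-fluorophenyl for 4-fluorophenyl gives an at least 1.8-fold lower number from compound 3 to compound 4 (0.25 log units; that floor lies within the scatter), which is the first sign that the place of the fluoro group on the phenyl group might matter, though that floor does not show it. Compound 3 has a limit of the assay and not a number, and this step is only a floor because of that limit: the limit of > 125000 nM in this assay, at which 1 of the 4 values shown sits.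

The compounds shown leave open whether a group other than fluoro or methoxy on the phenyl group, such as an amine or a carboxylic acid, would move the number beyond the scatter, as compounds 1, 2 and 4 all lie within the scatter of one another. They also leave open how far compound 3 truly stands from compound 4, and so whether moving the fluoro group has any real effect here.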